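A few compounds are considered here, and "the series" means these few. Any claim that something is new, unique, unknown or untested is made for them only; others in the source may bear on it.

In a functional assay on SK-OV-3 cells (Homo sapiens) for antiproliferative activity, read by sulforhodamine B assay, with a stated time of 72 h (a higher number here means a weaker inhibitor, a lower number a stronger inhibitor), compound 1 `Cc1cc(C)nc(NS(=O)(=O)c2ccc(Nc3nncc4ccccc34)cc2)n1` gives 0.08 nM and compound 2 `O=S(=O)(Nc1ccccn1)c1ccc(Nc2nncc3ccccc23)cc1` gives 0.9 nM, the higher of the two numbers. Compound 3 `Cc1cc(NS(=O)(=O)c2ccc(Nc3nncc4ccccc34)cc2)no1` has 5-methyl-1,2-oxazol-3-yl in place of pyridin-2-yl on a sulfonamide nitrogen. Among the compounds with values here, one measured step bears on this change at that nitrogen, and it is large: an 11-fold higher number from compound 1 to compound 2 (1.05 log units; beyond the scatter). Within the data shown here, no measured compound has a five-membered aromatic ring there, so direction and size remain uncertain. A moderate move toward a lower number is expected, estimated as a 2.3-fold lower number from compound 2 to compound 3 (0.35 log units; beyond the scatter). For compound 3, the estimated value is 0.4 nM, with an expected range of 0.08 nM to 2.5 nM.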

Compound 3, half-maximal inhibitory concentration: 6.7 nM
Beside the measured number, compound 3's estimate is 17-fold (1.22 log units) below it; measured number above the stated range.
By their numbers in this assay, from the lowest: compound 1; then compound 2; then compound 3.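

In this assay, 5-methyl-1,2-oxazol-3-yl on the sulfonamide nitrogen is a further loss from pyridin-2-yl, with a 7.4-fold higher number from compound 2 to compound 3 (0.87 log units; beyond the scatter) and, across the whole set at this nitrogen, an 84-fold higher number from compound 1 to compound 3 (1.92 log units; beyond the scatter) as the widest span so far. Both six-membered aromatic rings give lower numbers than this five-membered ring, but with a single five-membered example, ring size cannot be separated from its methyl group or its hetero atoms. No evidence on hand accounts for these steps.

Still open, from the compounds shown here alone, is how an unsubstituted 1,2-oxazol-3-yl or a plain phenyl ring on this nitrogen would read, which would separate the methyl group and the ring hetero atoms from ring size.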